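Replacing the benzyl of compound 2 with a thiourea group

The compounds below may be only part of what the source reports. "The series", "measured", "known", "first", "only" and "open" are said of these compounds alone.

Compound 2 `NC(=O)c1c(NC(=O)c2ccccc2Cl)sc2c1CCN(Cc1ccccc1Cl)C2` stands lowest of the two numbers in a functional assay on HeLa cells (Homo sapiens) for antiproliferative activity, with a stated time of 24 h (on this read-out lower numbers stand for stronger inhibition and higher numbers for weaker inhibition), with 27500 nM; compound 1 `NC(=O)c1c(NC(=O)c2ccccc2Cl)sc2c1CCN(Cc1ccccc1)C2` gives 38400 nM, and the step of a 1.4-fold lower number from compound 1 to compound 2 (0.14 log units; within the scatter). Compound 3 `COc1ccccc1NC(=S)N1CCc2c(sc(NC(=O)c3ccccc3Cl)c2C(N)=O)C1` reaches only a limit in this assay, > 50000 nM. For the measured compounds named here, the step of an at least 1.8-fold higher number from compound 2 to compound 3 (0.25 log units; that floor lies within the scatter) is the one that bears on compound 4 `COc1ccc(NC(=S)N2CCc3c(sc(NC(=O)c4ccccc4Cl)c3C(N)=O)C2)cc1`, whose change from compound 2 is a group of 11 heavy atoms (8 carbon, 1 nitrogen, 1 oxygen, 1 sulfur; one six-membered aromatic ring of carbon only) in place of a group of 8 heavy atoms (7 carbon, 1 chlorine; one six-membered aromatic ring of carbon only), on an amine nitrogen in a ring. Going by the values given here, the group entering compound 4 is built like the one in compound 3, so a similar move toward the limit is expected, though the floor of that step lies within the scatter. Compound 4 is therefore estimated at 55000 nM, between 20000 nM and 150000 nM, a step of a 2.0-fold higher number from compound 2 to compound 4 (0.30 log units; within the scatter) that may well end as a limit rather than a number.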

Compound 4, half-maximal inhibitory concentration: 36400 nM
The estimate for compound 4 lay 1.5-fold (0.18 log units) above the measured number; low and high end bracket the measured number.
By their numbers in this assay, from the lowest: compounds 2, 4 and 1 (each within the scatter of the next). At a limit, above all of these: compound 3.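

In this assay, the thiourea group of compound 4 gives a measured number, with a 1.3-fold higher number from compound 2 to compound 4 (0.12 log units; within the scatter) and a 1.1-fold lower number from compound 1 to compound 4 (0.02 log units; within the scatter), so at this ring nitrogen this thiourea is not separated from the two benzyl groups. The change to 4-methoxyphenyl in place of 2-methoxyphenyl gives an at least 1.3-fold lower number from compound 3 to compound 4 (0.13 log units; that floor lies within the scatter), so the methoxy shift is not resolved from the scatter. Compound 3 stands at a limit and not at a number: the limit of > 50000 nM in this assay, at which 1 of the 4 values shown sits.

The compounds shown leave open whether a urea in place of the thiourea, or a carboxylic acid in place of the methoxy group, would move the number beyond the scatter.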